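This account rests on a few compounds, and the source may have more. Where it says the series, first, only, none or still open, it means among the compounds named here.

Measured compounds:
- compound 1, `CC(=O)Nc1cccc(NC(=O)COc2ccc3c(=O)ccoc3c2)c1`: in an assay on isolated protein for inhibition of Rho-associated protein kinase 1 (Homo sapiens), read by scintillation counting, radiometric assay and 33P incorporation, with a stated time of 40 min, in the presence of a further agent that is not named here (a lower number here means a stronger inhibitor, a higher number a weaker inhibitor), compound 1 gives 2500 nM
- compound 2, `COc1ccc(C(=O)Nc2cccc(NC(=O)COc3ccc4c(=O)ccoc4c3)c2)cc1`: compound 2 gives 18 nM
- compound 3, `O=C(COc1ccc2c(=O)ccoc2c1)Nc1cccc(NC(=O)c2ccc([N+](=O)[O-])cc2)c1`: compound 3 gives 67 nM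

Compound 3 holds the second highest number of the three, with a 37-fold lower number from compound 1 to compound 3 (1.57 log units; beyond the scatter) and a 3.7-fold higher number from compound 2 to compound 3 (0.57 log units; beyond the scatter). Compound 4, `O=C(COc1ccc2c(=O)ccoc2c1)Nc1cccc(NC(=O)c2ccc(C(=O)O)cc2)c1`, differs from compound 3 in one place: carboxy in place of nitro on an aromatic carbon. Among the measured compounds shown here, no measured step exchanges a group at this position for carboxy; the nearest guide is a 3.7-fold higher number from compound 2 to compound 3 (0.57 log units; beyond the scatter), which shows that swapping the group on this aromatic carbon moves the number only modestly. A modest step in this assay, in either direction, is therefore expected for compound 4, most likely a small rise, a 1.8-fold higher number from compound 3 to compound 4 (0.25 log units; within the scatter). Compound 4 is estimated at 120 nM, within 35 nM to 400 nM.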

Compound 4, half-maximal inhibitory concentration: 6890 nM
Compound 4: the middle estimate sits 57-fold (1.76 log units) below what was measured; measured number outside the range, above it.
By their numbers in this assay, from the lowest: compound 2; then compound 3; then compound 1; then compound 4.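

In this assay, this position proves far less forgiving than the swap of methoxy for nitro suggested: carboxy in place of nitro gives a 100-fold higher number from compound 3 to compound 4 (2.01 log units; beyond the scatter), and carboxy in place of methoxy gives a 380-fold higher number from compound 2 to compound 4 (2.58 log units; beyond the scatter). The large aromatic group does not help on its own, since 4-carboxyphenyl in place of methyl gives a 2.8-fold higher number from compound 1 to compound 4 (0.44 log units; beyond the scatter), leaving the carboxy compound weaker than the small methyl amide. No available evidence explains this loss. Still open, as far as these compounds go, is whether an amine, a primary amide or a methyl ester here would behave like nitro or like carboxy.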